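The source may report more compounds than this note shows. Statements on the series, on what has been measured and on what is new or still open speak of the compounds shown alone.

The measured compounds and their values in a functional assay on DU-145 cells (Homo sapiens) for antiproliferative activity, read by MTT assay, with a stated time of 72 h; a higher number here means a weaker inhibitor, a lower number a stronger inhibitor:

Compound 1, `COc1cc2c(Nc3ccc(C#N)cc3)ncnc2cc1OCCCN(C)C`, gives 35300 nM.
Compound 2, `COc1cc2c(Nc3ccc(C#N)cc3)ncnc2cc1OCCCN(C)Cc1ccccc1`, gives > 100000 nM, which is a limit of this assay rather than a number.
Compound 3, `CCOC(=O)C1CCN(CCCOc2cc3ncnc(Nc4ccc(C#N)cc4)c3cc2OC)CC1`, gives 52300 nM.

Compound 2 therefore stands only at a limit, the point noted as the limit of > 100000 nM in this assay, at which 1 of the 3 values shown sits, and no exact figure is known for it. Compound 4, `CCN1CCN(CCCOc2cc3ncnc(Nc4ccc(C#N)cc4)c3cc2OC)CC1`, has not yet been measured in this assay. It differs from compound 2 as follows: 4-ethylpiperazin-1-yl in place of benzyl(methyl)amino on a saturated chain carbon, three bonds along the chain from an oxygen on an aromatic ring.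

For the measured compounds named here, two measured steps bear on this change. The closest is an at least 1.9-fold lower number from compound 2 to compound 3 (0.28 log units; that floor lies within the scatter), where benzyl(methyl)amino likewise gives way to a cyclic amine. The step of an at least 2.8-fold higher number from compound 1 to compound 2 (0.45 log units; beyond the scatter) shows that adding phenyl to the amine raised the number, and compound 4 removes that phenyl again. The step of a 1.5-fold higher number from compound 1 to compound 3 (0.17 log units; within the scatter) shows that exchanging one amine for another left the number within the scatter.

Compound 4 is therefore expected to return to roughly the range of compound 1 and compound 3, a modest step downward of an at least 2.5-fold lower number from compound 2 to compound 4 (0.39 log units; beyond the scatter). Compound 4 is estimated at 40000 nM, with a range from 15000 nM to 100000 nM.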

Compound 4, half-maximal inhibitory concentration: 34400 nM
Compound 4: middle estimate off by 1.2-fold (0.07 log units), on the high side; the range from low to high includes it.
By their numbers in this assay, from the lowest: compounds 4, 1 and 3 (each within the scatter of the next). At a limit, above all of these: compound 2.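

In this assay compound 2 stands only at a limit, not at a number: the limit of > 100000 nM in this assay, at which 1 of the 4 values shown sits. Replacing benzyl(methyl)amino with 4-ethylpiperazin-1-yl on this chain gives an at least 2.9-fold lower number from compound 2 to compound 4 (0.46 log units; beyond the scatter), so a cyclic amine in this place now shows a step beyond the scatter, which the floor of an at least 1.9-fold lower number from compound 2 to compound 3 (0.28 log units; that floor lies within the scatter) could not show. The other two steps, a 1.5-fold lower number from compound 3 to compound 4 (0.18 log units; within the scatter) and a 1.0-fold lower number from compound 1 to compound 4 (0.01 log units; within the scatter), stay within the scatter, so dimethylamino, 4-(ethoxycarbonyl)piperidin-1-yl and 4-ethylpiperazin-1-yl cannot be told apart here, and only benzyl(methyl)amino stands apart.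

Still open, as far as these compounds go, is whether a 4-benzylpiperazin-1-yl group would also raise the number, which would show if the phenyl has the same effect on a ring amine. Also open, from the compounds shown here alone, is whether a morpholine ring, a free carboxylic acid in place of the ethyl ester, or a longer chain would separate from these three amines.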